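Dihydrobenzopyran series: nitrile in place of furoyl

The compounds below may be only part of what the source reports. "The series", "measured", "known", "first", "only" and "open" are said of these compounds alone.

Measured so far:
Compound 1 `CC1(C)C=C(n2ccccc2=O)c2cc(C(=O)c3ccco3)ccc2O1`, a functional assay (trachea) with Rattus norvegicus as the target; a lower number here means a less potent compound, a higher number a more potent compound, by a factor of ten per unit of this negative logarithm: 5.92
Compound 2 `CC1(C)C=C(n2ccccc2=O)c2cc(C(=O)c3ccccc3[N+](=O)[O-])ccc2O1`, this assay: 5.64

Compound 1 and compound 2 share the core and differ only on the carbonyl carbon, 2-nitrophenyl in place of furan-2-yl. Among the measured compounds shown here, the single measured step, a number 0.28 log units lower from compound 1 to compound 2 (within the scatter), lies within the scatter, so the two numbers cannot be told apart and compound 1 has no standing above compound 2 in this assay beyond that of giving one of two equivalent readings.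

Compound 3 `CC1(C)C=C(n2ccccc2=O)c2cc(C#N)ccc2O1` is not yet measured. It differs from compound 1 as follows: cyano in place of (furan-2-yl)carbonyl on an aromatic carbon. For the measured compounds named here, this change removes the whole (furan-2-yl)carbonyl group rather than swapping the ring on the carbonyl carbon, so the one measured step bears on it only loosely: it shows that the ring on the carbonyl may be exchanged at no cost, but says nothing about replacing the carbonyl itself with cyano. Going by the values given here, with no direct precedent, a modest loss is estimated, while a result within the scatter of compound 1 cannot be ruled out. For compound 3 the estimated step is a number 0.42 log units lower from compound 1 to compound 3 (beyond the scatter). Compound 3 is thus expected to give 5.5 in this assay, with a range from 4.8 to 6.2.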

Compound 3, logarithm of the reciprocal of the active concentration, log(1/C): 7.1
Compound 3: middle estimate off by 1.60 log units, on the low side; measured number outside the range, above it.
By their numbers in this assay, from the lowest: compounds 2 and 1 (each within the scatter of the next); then compound 3.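

In this assay, the position on the aromatic carbon proves far more sensitive to replacing the whole substituent than to exchanging the ring on the carbonyl carbon: cyano in place of (furan-2-yl)carbonyl gives a number 1.18 log units higher from compound 1 to compound 3 (beyond the scatter), whereas the earlier change gives a number 0.28 log units lower from compound 1 to compound 2 (within the scatter). Neither the carbonyl nor its attached ring is therefore required for activity in this assay at this place, and the nitrile, with 2 heavy atoms against 7 in the group it replaces, gives the highest number of the three compounds. No measurement at hand bears on what lies behind this step.

The step from compound 1 to compound 3 removes the carbonyl and the furan ring and introduces the nitrile all at once, so the compounds shown cannot assign the gain to any one of these changes. Open, going by these compounds, is how simpler replacements at the same place, such as an acetyl group, a carboxylic acid, a primary amide or a chlorine atom, would compare with the nitrile in this assay.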